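Swapping the halogenated phenyl on the amine of compound 2

This account rests on a few compounds, and the source may have more. Where it says the series, first, only, none or still open, it means among the compounds named here.

Compound 1, `COc1ccccc1NC1=CC(=O)c2c(nc3n2[C@H]2OC[C@@H](O)[C@H]2OC3)C1=O`: 1670 nM
Compound 2, `O=C1C=C(Nc2cccc(F)c2)C(=O)c2c1nc1n2[C@H]2OC[C@@H](O)[C@H]2OC1`: 2180 nM
Compound 3, `O=C1C(N2CCC2)=CC(=O)c2c1nc1n2[C@H]2OC[C@@H](O)[C@H]2OC1`: > 16000 nM

In a functional assay on MGC-803 cells (Homo sapiens) for inhibition, read by sulforhodamine B assay (on this read-out higher numbers stand for weaker inhibition and lower numbers for stronger inhibition), compound 1 gives 1670 nM and compound 2 gives 2180 nM. Compound 2 thus holds the highest of the two numbers given, but its gap to compound 1 lies within the scatter, so the two cannot be told apart. For compound 3 the read-out in this assay is only a limit, > 16000 nM, not a number. Among the measured compounds shown here, the one step that can be sized, an at least 9.5-fold higher number from compound 1 to compound 3 (0.98 log units; beyond the scatter), shows that exchanging the arylamino group for a small cyclic amine costs inhibition; it rests on (the limit of > 16000 nM in this assay, at which 1 of the 3 values shown sits).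

Compound 4, `O=C1C=C(Nc2ccc(I)cc2)C(=O)c2c1nc1n2[C@H]2OC[C@@H](O)[C@H]2OC1`, has not been measured. It differs from compound 2 by 4-iodophenyl in place of 3-fluorophenyl on an amine nitrogen. Both compounds keep an arylamino group on the double-bonded ring carbon, so the measured step from compound 1 to compound 3, which removes that group, does not bear on this change. For the measured compounds named here, no measured pair shows what exchanging one halogenated phenyl for another does here. The expectation is therefore a step of a 1.1-fold lower number from compound 2 to compound 4 (0.04 log units; within the scatter), not beyond the scatter. Compound 4 is estimated at 2000 nM, between 800 nM and 5500 nM.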

Compound 4, half-maximal inhibitory concentration: 1400 nM
Estimate against measurement, compound 4: 1.4-fold (0.15 log units) above; the measured number falls inside the stated range.
By their numbers in this assay, from the lowest: compounds 4, 1 and 2 (each within the scatter of the next). At a limit, above all of these: compound 3.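

In this assay, putting 4-iodophenyl in place of 3-fluorophenyl on the amine nitrogen gives a 1.6-fold lower number from compound 2 to compound 4 (0.19 log units; within the scatter), so compound 2 and compound 4 cannot be told apart. Among the compounds shown here, this is the first measured pair in which one halogenated phenyl replaces another, and it shows that inhibition at this level survives a swap of both the halogen and its place on the phenyl ring, though a single pair cannot separate those two differences or establish a general rule. Nothing measured here explains why the two compounds read alike.

The compounds shown leave open whether the halogen matters at all, as plain phenyl on the same amine nitrogen, or 4-fluorophenyl and 3-iodophenyl, which would separate the halogen from its place, are not among them. They also leave open how far the aromatic ring itself is needed, which a benzyl group or an open butyl chain on the same nitrogen could test against the halogenated phenyl groups.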